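The source may report more compounds than this note shows. Statements on the series, on what has been measured and on what is new or still open speak of the compounds shown alone.

Three compounds have so far been measured in a functional assay on Huh-7 cells (Homo sapiens) for inhibition, read by sulforhodamine B assay, with a stated time of 72 h; on this read-out lower numbers stand for stronger inhibition and higher numbers for weaker inhibition:

compound 1 `COc1cc(C(=O)/C=C/c2cn(-c3ccccc3)nc2-c2ccsc2)cc(OC)c1OC`, 3600 nM
compound 2 `COc1cc(OC)c(C(=O)/C=C/c2cn(-c3ccccc3)nc2-c2ccsc2)c(OC)c1`, 6100 nM
compound 3 `O=C(/C=C/c1cn(-c2ccccc2)nc1-c1cccnc1)c1ccsc1`, 1700 nM

Among these three, compound 3 shows the lowest number and is therefore the strongest inhibitor of the set. Compound 1 stands nearest to it, with a higher number that already lies beyond the usual scatter, and compound 2 stands furthest away, with a number higher still and clearly beyond the scatter.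

The step now followed leads from compound 3 to compound 4 `O=C(/C=C/c1cn(-c2ccccc2)nc1-c1cccnc1)c1ccccc1`, which has not yet been measured in this assay. The change is phenyl in place of thiophen-3-yl on a carbonyl carbon. For the measured compounds named here, no pair of measured compounds differs in this one place alone, so the data give no direct guide to the size of this step. He expects a small step, if any, from compound 3 to compound 4, not beyond the scatter, in either direction. For compound 4 in this assay the estimated value is 2000 nM, with a range from 800 nM to 5000 nM, which is expected to mean a step of a 1.2-fold higher number from compound 3 to compound 4 (0.07 log units; within the scatter).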

Compound 4, half-maximal inhibitory concentration: 2300 nM
Compound 4: the middle estimate sits 1.2-fold (0.06 log units) below what was measured; the measured number falls inside the stated range.
By their numbers in this assay, from the lowest: compounds 3, 4, 1 and 2 (each within the scatter of the next, the first and the last beyond it).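

In this assay, for the compounds shown here, the exchange of thiophen-3-yl for phenyl on a carbonyl carbon gives a 1.4-fold higher number from compound 3 to compound 4 (0.13 log units; within the scatter), the first direct reading of a change at this place alone. At this place, then, a six-membered aromatic ring of carbon only can stand in for a five-membered aromatic ring with a sulfur atom, with no change that can be told from the usual scatter. Nothing at hand bears on why this exchange leaves the number within the scatter.

What the compounds shown leave open is how far this holds beyond these two aromatic rings, for instance for a cyclohexyl ring or a short alkyl chain on the carbonyl carbon. On these data alone, it also remains open whether a phenyl ring carrying an amine or a carboxylic acid would give a larger step.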